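The compounds below may be only part of what the source reports. "The series", "measured", "known", "first", "only" and "open" are said of these compounds alone.

Measured so far in a functional assay on CWR22R cells (Homo sapiens) for antiproliferative activity, with a stated time of 96 h; a lower number here means a stronger inhibitor, a higher number a weaker inhibitor:
- compound 1 `Cc1cc(=O)oc2cc(OCC(=O)c3ccc(C(C)(C)C)cc3)ccc12`: 22300 nM
- compound 2 `CC(C)(C)c1ccc(C(=O)COc2ccc3c(C(F)(F)F)cc(=O)oc3c2)cc1`: "not active" (no number reported)

Compound 2 has no number to stand on. In this assay compound 2 is simply reported as "not active" (no number reported), so it can only be placed behind compound 1, which does give a number, 22300 nM.

The next structure is compound 3 `COc1ccc(C(=O)COc2ccc3c(C(F)(F)F)cc(=O)oc3c2)cc1`. Among the measured compounds shown here, the single structural change is methoxy in place of tert-butyl on an aromatic carbon, para to a large group.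

For the measured compounds named here, no measured pair shows what this swap does, so any step in this assay is a judgement. The expectation is a modest move toward measurable activity, and compound 3 may again give no number. The only scale available comes from compound 1 at 22300 nM. For compound 3 the estimated value is 30000 nM, with an expected range of 10000 nM to 90000 nM.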

Compound 3, half-maximal inhibitory concentration: "not active" (no number reported)
The entry for compound 3 holds no number; there is nothing to compare the estimate with.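

In this assay compound 2 and compound 3 are both reported as not active, without a number, so no step can be read between them. As far as these compounds go, how far methoxy in place of tert-butyl shifts activity stays open, and no available evidence bears on this result.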